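The source may report more compounds than this note shows. Statements on the series, on what has been measured and on what is new or still open speak of the compounds shown alone.

Of the compounds shown here, three with a shared core have been measured in a functional assay on HEK293 cells for agonist activity at G-protein coupled receptor 39 (Homo sapiens), read by scintillation proximity assay and inositol phosphate accumulation, with a stated time of 75 min; on this read-out lower numbers stand for an effect already at smaller amounts and higher numbers for an effect only at larger amounts of compound. Compound 1 `Cc1nn(-c2ncnc3nc[nH]c23)c2c1C(OCc1ccc(Cl)cc1Cl)CC(=O)N2` gives 243 nM, compound 2 `Cc1nn(-c2ncnc3nc[nH]c23)c2c1C(OCc1ccc(C#N)cc1)CC(=O)N2` gives 60 nM, and compound 3 `Cc1nn(-c2ncnc3nc[nH]c23)c2c1C(NC(=O)c1ccccc1)CC(=O)N2` gives 158 nM. Within this small set, compound 3 sits second highest of the three numbers: the change in this assay a 1.5-fold lower number from compound 1 to compound 3 (0.19 log units; within the scatter) is too small to tell the two apart, whereas the change a 2.6-fold higher number from compound 2 to compound 3 (0.42 log units; beyond the scatter) is a modest but real weakening.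

Compound 4 `Cc1nn(-c2ncnc3nc[nH]c23)c2c1C(C(=O)N(C)c1ccccc1)CC(=O)N2` differs from compound 3 in one place: methyl(phenyl)carbamoyl in place of benzamido on a saturated ring carbon. The amide is thereby turned around, so that the carbonyl now sits on the ring carbon and the nitrogen carries a methyl and a phenyl instead of a hydrogen.

Among the measured compounds shown here, none of the measured steps tests such a reversal. The two steps that reach compound 3, a 1.5-fold lower number from compound 1 to compound 3 (0.19 log units; within the scatter) and a 2.6-fold higher number from compound 2 to compound 3 (0.42 log units; beyond the scatter), only show that swapping a benzyl ether for a benzamido group at this position moves the number by a modest amount or not at all. That suggests this position tolerates different linkers without large shifts, so a step within or near the scatter, probably toward a somewhat higher number, is expected for compound 4, a 1.6-fold higher number from compound 3 to compound 4 (0.20 log units; within the scatter). The estimate for compound 4 in this assay is 250 nM, with a likely range from 70 nM to 900 nM.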

Compound 4, half-maximal effective concentration: 5220 nM
Beside the measured number, compound 4's estimate is 21-fold (1.32 log units) below it; measured number above the stated range.
By their numbers in this assay, from the lowest: compound 2; then compounds 3 and 1 (each within the scatter of the next); then compound 4.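

Until now, changing the group on this saturated ring carbon had moved the number only a little, so the position looked tolerant. Methyl(phenyl)carbamoyl shows that it is not tolerant of every linker, giving a 33-fold higher number from compound 3 to compound 4 (1.52 log units; beyond the scatter), while the same replacement of the two benzyl ether groups gives an 87-fold higher number from compound 2 to compound 4 (1.94 log units; beyond the scatter) and a 21-fold higher number from compound 1 to compound 4 (1.33 log units; beyond the scatter). Benzamido and methyl(phenyl)carbamoyl each carry one six-membered aromatic ring of carbon only and one hydrogen-bond acceptor, so an aromatic ring and an acceptor at this position do not by themselves keep the number low, and no measurement shown here explains the large step.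

Compound 4 differs from compound 3 in two features at once, the turned-around amide and the loss of the amide hydrogen in favour of a methyl, so the compounds shown cannot say which one matters; phenylcarbamoyl, the turned-around amide that keeps its hydrogen, would separate them. Also open, from the compounds shown here alone, is how this ring carbon responds to a group without an aromatic ring, such as a primary amine or a carboxylic acid.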